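The source may report more compounds than this note shows. Statements on the series, on what has been measured and on what is new or still open speak of the compounds shown alone.

In a physicochemical assay for solubility, in phosphate buffer, measured as kinetic solubility, with a stated time of 1 h, at pH 7.4 (on this read-out higher numbers stand for higher solubility and lower numbers for lower solubility), compound 1 (`CC(C)(c1cc([C@@]23CCOC[C@@H]2C3)nc(-c2cccc(O)c2)n1)S(C)(=O)=O`) gives 148 ug/mL, compound 2 (`CNCC(=O)Nc1ccc(-c2nc(CS(C)(=O)=O)cc([C@@]34CCOC[C@@H]3C4)n2)cc1`) gives 167 ug/mL and compound 3 (`Oc1cccc(-c2nccc([C@@]34CCOC[C@@H]3C4)n2)c1`) gives 123 ug/mL, so compound 3 lies within the scatter of both others. Compound 4 (`Oc1cccc(-c2nccc([C@]34CCOC[C@H]3C4)n2)c1`) relates to compound 3 as follows: the two compounds have the same atoms and bonds and differ only in configuration as drawn: 2 of 2 stereo elements differ (all stereocentres are inverted: mirror images); a stereocentre at a saturated ring carbon is drawn S in compound 3 and R in compound 4; a stereocentre at a saturated ring carbon is drawn R in compound 3 and S in compound 4. Among the measured compounds shown here, the only measured step is a 1.2-fold lower number from compound 1 to compound 3 (0.08 log units; within the scatter), and it leaves the configuration untouched. For the measured compounds named here, the data therefore contain no measured pair of mirror images, and no step tests such an inversion directly. With nothing pointing to a shift, the estimated step in this assay is no change at the digits printed from compound 3 to compound 4 (within the scatter), with none expected beyond the scatter. For compound 4 the expected value is 123 ug/mL, with an estimated range of 75 ug/mL to 190 ug/mL.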

Compound 4, solubility: 141 ug/mL
Compound 4: middle estimate off by 1.1-fold (0.06 log units), on the low side, within the range that was stated.
By their numbers in this assay, from the lowest: compounds 3, 4, 1 and 2 (each within the scatter of the next).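

In this assay, inverting both stereocentres gives a 1.1-fold higher number from compound 3 to compound 4 (0.06 log units; within the scatter), the first direct test of this change in the series. For this pair, the configuration of the saturated ring carbons therefore leaves no mark on the read-out beyond the scatter. The comparison is clean on one point: the fact that compounds 3 and 4 differ only in the configuration as drawn

The compounds shown leave open whether the mirror-image pair would read as closely with 1-methyl-1-(methylsulfonyl)ethyl on the shared core, as in compound 1. They also leave open whether it would do so with a carboxylic acid in place of the hydroxyl group.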